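A few compounds are considered here, and "the series" means these few. Any claim that something is new, unique, unknown or untested is made for them only; others in the source may bear on it.

In a functional assay on HepG2 cells (Homo sapiens) for cytotoxicity, read by MTT assay, with a stated time of 24 h (on this read-out lower numbers stand for stronger inhibition and higher numbers for weaker inhibition), compound 3 (`O=C1/C(=C/c2ccncc2)CN(S(=O)(=O)c2ccc(C(F)(F)F)cc2)C/C1=C\c1ccccc1F`) gives 4030 nM and lies within the scatter of compound 2 (`O=C1/C(=C/c2cccnc2)CN(S(=O)(=O)c2ccc(C(F)(F)F)cc2)C/C1=C\c1ccccc1F`) at 2400 nM while compound 1 (`CN1C/C(=C\c2ccc(C#N)cc2)C(=O)/C(=C/c2cccnc2)C1`) stands at 12700 nM on a higher number, beyond the scatter from compound 3.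

The next entry is compound 4 (`CC(=O)Nc1ccc(S(=O)(=O)N2C/C(=C\c3ccncc3)C(=O)/C(=C/c3ccccc3F)C2)cc1`). The difference from compound 3 is acetamido in place of trifluoromethyl on an aromatic carbon and in words it is acetamido in place of trifluoromethyl on an aromatic carbon, para to a large group. The same difference also reads 4-(trifluoromethyl)phenyl to 4-acetamidophenyl.

Among the measured compounds shown here, the only measured step that differs in one place is a 1.7-fold higher number from compound 2 to compound 3 (0.23 log units; within the scatter) and it exchanges pyridin-3-yl for pyridin-4-yl elsewhere in the molecule, so it bears on this change only indirectly. Compound 1 differs from compound 3 in several places at once and isolates nothing. No measured pair tests this substituent, and the range is kept wide for that reason.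

The expected step in this assay is a 1.2-fold higher number from compound 3 to compound 4 (0.09 log units; within the scatter) and so no shift beyond the scatter is expected, only a slight lean toward a higher number. For compound 4 the estimate is 5000 nM with an expected range from 1800 nM to 14000 nM in this read-out.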

Compound 4, half-maximal inhibitory concentration: 11700 nM
Beside the measured number, compound 4's estimate is 2.3-fold (0.37 log units) below it; the range from low to high includes it.
By their numbers in this assay, from the lowest: compounds 2 and 3 (each within the scatter of the next); then compounds 4 and 1 (each within the scatter of the next).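

In this assay, acetamido in place of trifluoromethyl on an aromatic carbon, para to a large group, gives a 2.9-fold higher number from compound 3 to compound 4 (0.46 log units; beyond the scatter). This is the first one-place change shown on the 4-(trifluoromethyl)phenyl side of the series, and it moves the number beyond the scatter, whereas the only earlier one-place step, a 1.7-fold higher number from compound 2 to compound 3 (0.23 log units; within the scatter), exchanged pyridin-3-yl for pyridin-4-yl and stayed within it. The leaving and entering groups have the same count of heavy atoms, while acetamido carries a hydrogen-bond donor and a hydrogen-bond acceptor that trifluoromethyl lacks, but no measurement given here shows which of these differences, if any, accounts for the step.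

Whether acetamido gives a step of similar size alongside pyridin-3-yl, as in compound 2, remains open, since this change is shown on the pyridin-4-yl compounds only. Also open, going by these compounds, is how an amine, a carboxylic acid or a longer acyl chain on the same aromatic carbon would read in this assay, so a single pair gives no trend for this position.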